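Trifluoromethoxy in place of trifluoromethyl on the shared core

The source may report more compounds than this note shows. Statements on the series, on what has been measured and on what is new or still open speak of the compounds shown alone.

In a functional assay on A549 cells (Homo sapiens) for inhibition, read by sulforhodamine B assay (a higher number here means a weaker inhibitor of growth, a lower number a stronger inhibitor of growth), compound 1 (`Fc1ccc(-c2ccc(-c3ccc(-c4nc5ccccc5[nH]4)cc3)cc2)cc1`) gives 33200 nM and compound 2 (`FC(F)(F)c1ccc(-c2ccc(-c3ccc(-c4nc5ccccc5[nH]4)cc3)cc2)cc1`) gives 36600 nM. Compound 2 therefore stands within the scatter of compound 1, and the two numbers set up no order. The next structure is compound 3 (`FC(F)(F)Oc1ccc(-c2ccc(-c3ccc(-c4nc5ccccc5[nH]4)cc3)cc2)cc1`), which has trifluoromethoxy in place of trifluoromethyl on an aromatic carbon, para to a large group: trifluoromethoxy in place of trifluoromethyl on an aromatic carbon. For the measured compounds named here, only one measured step bears on this change. That step, a 1.1-fold higher number from compound 1 to compound 2 (0.04 log units; within the scatter), is trifluoromethyl in place of fluoro at the same aromatic carbon, and it stays within the scatter. Going by the values given here, one step is thin evidence, and no measured compound yet carries trifluoromethoxy. Even so, the flat result at this carbon gives no reason to expect a real shift in this assay, in either direction. The expected change is a 1.0-fold lower number from compound 2 to compound 3 (0.02 log units; within the scatter), which is no step beyond the scatter. Compound 3 is estimated at 35000 nM, with an expected range from 18000 nM to 65000 nM.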

Compound 3, concentration for 50% growth inhibition: 38000 nM
Compound 3: the middle estimate sits 1.1-fold (0.04 log units) below what was measured, and the stated range covers the measured number.
By their numbers in this assay, from the lowest: compounds 1, 2 and 3 (each within the scatter of the next).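

At the aromatic carbon para to a large group, swapping trifluoromethyl for trifluoromethoxy brings in an oxygen, yet this assay shows a 1.0-fold higher number from compound 2 to compound 3 (0.02 log units; within the scatter) and so gives no separation between the two groups. The comparison with fluoro reads the same, with a 1.1-fold higher number from compound 1 to compound 3 (0.06 log units; within the scatter) as the step, so this carbon now has three groups that cannot be told apart, where before there was a single pair. No measurement is at hand that would account for this lack of separation.

As far as these compounds go, all three groups at this carbon are fluorinated, so it remains open whether a group of a different kind, such as an amine, a carboxylic acid or a longer alkyl chain, would give a number beyond the scatter of these three. It also remains open whether changes elsewhere on the shared core would give a step beyond the scatter in this assay, as the compounds shown differ only at this one carbon.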